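Cytotoxicity Outlook for Compound 3 on JM1 Cells

A few compounds are considered here, and "the series" means these few. Any claim that something is new, unique, unknown or untested is made for them only; others in the source may bear on it.

For the measured compounds named here, compound 1 `CSCO[C@@]1(C)CO[C@@](C)(CC(=O)OC[C@H]2O[C@@H](n3cc(C)c(=O)[nH]c3=O)C[C@@H]2O)C1` was tested in a functional assay on JM1 cells (Homo sapiens) for cytotoxicity (on this read-out higher numbers stand for lower toxicity in this test and lower numbers for higher toxicity in this test), where compound 1 gives 400000 nM, the only number recorded for it alongside one further entry without a single number. Compound 2 `Cc1cn([C@H]2C[C@H](O[Si](C)(C)C(C)(C)C)[C@@H](COC(=O)CC3(C)CC(C)(O)CO3)O2)c(=O)[nH]c1=O` is a related ester, and in this assay compound 2 gives 200000 nM; 200000 nM (2 entries); these two readings lie within the usual scatter of each other. Compound 3 `CSCO[C@@]1(C)CO[C@@](C)(CC(=O)OC[C@H]2O[C@@H](n3cc(C)c(=O)[nH]c3=O)C[C@@H]2O[Si](C)(C)C(C)(C)C)C1` has not yet been measured. It differs from compound 1 by a group of 7 heavy atoms (6 carbon, 1 silicon; no ring) in place of a hydrogen atom, on an oxygen on a saturated carbon. Going by the values given here, no step between two measured compounds with a single change of this kind is available, so the expectation rests on the weak toxicity seen so far. Compound 3 is expected to show a step of a 1.6-fold lower number from compound 1 to compound 3 (0.20 log units; within the scatter), which would not go beyond the scatter. Compound 3 is therefore estimated at 250000 nM, within a range from 80000 nM to 800000 nM.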

Compound 3, half-maximal cytotoxic concentration: 80000 nM
Estimate against measurement, compound 3: 3.1-fold (0.49 log units) above; the measured number falls inside the stated range.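

In this assay, putting the group of 7 heavy atoms (6 carbon, 1 silicon) in place of a hydrogen atom on this oxygen gives a 5.0-fold lower number from compound 1 to compound 3 (0.70 log units; beyond the scatter). For the compounds shown here, this is the first single change read at this position, and it shows that the position is not silent: capping the oxygen moves the read-out towards higher toxicity in this test. No measurement shown here explains why the number moves.

Going by these compounds, it remains open whether a much smaller group on the same oxygen, such as a methyl or an acetyl, would shift the number too, and whether the silicon atom matters, which an all-carbon group of similar shape could test. This is a single step on the core of compound 1, so it cannot yet be called a general pattern.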